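This account rests on a few compounds, and the source may have more. Where it says the series, first, only, none or still open, it means among the compounds named here.

Values in an ADME assay on HT-29 cells (Homo sapiens) for inhibition, read by MTT assay, with a stated time of 72 h; on this read-out higher numbers stand for weaker inhibition and lower numbers for stronger inhibition:

compound 1 `C=CC(=O)Nc1cccc(Nc2nc(N/N=C(\C)c3ccc(F)cc3)ncc2Cl)c1`: 5050 nM
compound 2 `C=CC(=O)Nc1cccc(Nc2nc(N/N=C(\C)c3ccc(F)cc3F)ncc2Cl)c1`: 4360 nM
compound 3 `C/C(=N\Nc1ncc(Cl)c(Nc2cccc(NC(=O)/C=C/CN(C)C)c2)n1)c1ccc(F)cc1`: 10200 nM

Compound 2 differs from compound 1 by fluoro in place of hydrogen on an aromatic carbon and the step is a 1.2-fold lower number from compound 1 to compound 2 (0.06 log units; within the scatter). Compound 3 differs from compound 1 in its core by 3-(dimethylamino)prop-1-en-1-yl in place of vinyl on a carbonyl carbon; the step is a 2.0-fold higher number from compound 1 to compound 3 (0.31 log units; beyond the scatter). Compound 4 `C/C(=N\Nc1ncc(Cl)c(Nc2cccc(NC(=O)/C=C/CN(C)C)c2)n1)c1ccc(F)cc1F` is not yet measured in this assay. It differs from compound 3 by fluoro in place of hydrogen on an aromatic carbon, the same change as that from compound 1 to compound 2, at a place described in the same words. The expectation rests on that single earlier step, a 1.2-fold lower number from compound 1 to compound 2 (0.06 log units; within the scatter), applied to the value of compound 3, 10200 nM; on that basis the step from compound 3 to compound 4 is expected to be a 1.2-fold lower number from compound 3 to compound 4 (0.08 log units; within the scatter). Compound 4 is therefore estimated at 8500 nM, expected to fall between 4500 nM and 16000 nM.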

Compound 4, half-maximal inhibitory concentration: 3460 nM
Estimate against measurement, compound 4: 2.5-fold (0.39 log units) above, and the stated range ends above it.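

In this assay, the change from 4-fluorophenyl to 2,4-difluorophenyl gives a 2.9-fold lower number from compound 3 to compound 4 (0.47 log units; beyond the scatter), and 3-(dimethylamino)prop-1-en-1-yl in place of vinyl gives a 1.3-fold lower number from compound 2 to compound 4 (0.10 log units; within the scatter). The fluoro change carries from one core to the other with no difference that stands clear of the scatter: the same change on two cores in this assay, a 1.2-fold lower number (0.06 log units; within the scatter) from compound 1 to compound 2 and a 2.9-fold lower number (0.47 log units; beyond the scatter) from compound 3 to compound 4, 2.5-fold (0.41 log units) apart, within the scatter of two such steps. Within the data shown here, the other change reads the same way, yet with only one pair of steps for each change this shows no measured core dependence and does not show that either step is the same on both cores: the same change on two cores in this assay, a 2.0-fold higher number (0.31 log units; beyond the scatter) from compound 1 to compound 3 and a 1.3-fold lower number (0.10 log units; within the scatter) from compound 2 to compound 4, 2.5-fold (0.41 log units) apart, within the scatter of two such steps.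

The compounds shown leave open whether a chloro or methoxy group on the same ring would follow the fluoro step. Also open, on these data alone, is whether a morpholine or a longer chain in place of the dimethylamino group would carry between the cores in the same way.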